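Swapping Chloro for Methoxy on the Aryl Ring

A few compounds are considered here, and "the series" means these few. Any claim that something is new, unique, unknown or untested is made for them only; others in the source may bear on it.

Compound 1, `O=C(NCCCCc1ccccc1)n1c(-c2ccccc2)coc1=O`, gives 70 nM in an assay on isolated protein for inhibition of acid ceramidase (Homo sapiens), read by LC-MS, with a stated time of 1 h; on this read-out higher numbers stand for weaker inhibition and lower numbers for stronger inhibition.
Compound 2, `CCCCCNC(=O)n1c(-c2ccccc2)coc1=O`, gives 25 nM in this assay.
Compound 3, `O=C(NCCCCc1ccccc1)n1cc(-c2ccc(Cl)cc2)oc1=O`, gives 83 nM in this assay.

Compound 3 carries the highest of the three numbers shown, but its gap to compound 1 is within the scatter, so those two cannot be told apart; only compound 2 sits clearly apart from it. Among the measured compounds shown here, the one step measured between single-change neighbours is a 2.8-fold lower number from compound 1 to compound 2 (0.45 log units; beyond the scatter), a change at the far end of the chain, not on the aryl ring.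

Compound 4, `COc1ccc(-c2cn(C(=O)NCCCCc3ccccc3)c(=O)o2)cc1`, differs from compound 3 by methoxy in place of chloro on an aromatic carbon, on an aromatic carbon of the six-membered ring of carbon only, para to a large group. For the measured compounds named here, no measured pair touches that ring, and the chain step between compound 1 and compound 2 says nothing about an aryl substituent. With nothing in hand pointing either way, the expected step in this assay is a 1.1-fold higher number from compound 3 to compound 4 (0.04 log units; within the scatter), none beyond the scatter. Compound 4 is therefore estimated at 90 nM, with a plausible range from 35 nM to 230 nM.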

Compound 4, half-maximal inhibitory concentration: 400 nM
The estimate for compound 4 lay 4.4-fold (0.65 log units) below the measured number, outside the stated range (above it).
By their numbers in this assay, from the lowest: compound 2; then compounds 1 and 3 (each within the scatter of the next); then compound 4.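

In this assay, among the compounds shown here, the first measured change on this aryl ring, from 4-chlorophenyl to 4-methoxyphenyl, gives a 4.8-fold higher number from compound 3 to compound 4 (0.68 log units; beyond the scatter) and so weakens inhibition. The earlier step showed only that the far end of the chain can shift the number, whereas this one shows that the group on an aromatic carbon, para to a large group, is not a free choice either, and that methoxy is the worse of the two groups tried there. Methoxy brings one more heavy atom than chloro and one hydrogen-bond acceptor, but nothing measured here links either difference to the weaker inhibition or offers any explanation for the step.

For the compounds shown here, with only two groups compared at this place, a single step cannot show a trend, so it remains open whether a hydrogen, a fluoro, a methyl or a hydroxy would give a number closer to that of compound 3 or that of compound 4. On these data alone, it is also open whether methoxy would cost as much when paired with the chain of compound 2.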